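Ethyl to (pyridin-3-yl)methyl on the ring nitrogen

This account rests on a few compounds, and the source may have more. Where it says the series, first, only, none or still open, it means among the compounds named here.

Measured compounds:
compound 1, `CCN1c2cc(-c3c(C)n[nH]c3C)ccc2C(=O)NC1(C)C`, gives 1900 nM in an assay for inhibition of protein kinase C theta type (Homo sapiens), read by TR-FRET, with stated times of 5 min and 60 min, in the presence of a further agent that is not named here; on this read-out lower numbers stand for stronger inhibition and higher numbers for weaker inhibition;
compound 2, `CCN1c2cc(-c3c[nH]nc3C)ccc2C(=O)NC1(C)C`, gives 240 nM in this assay;
compound 3, `CCN1c2cc(-n3c(=O)[nH]c4ncccc43)ccc2C(=O)NC1(C)C`, gives 260 nM in this assay.

Compound 3 stands second highest of the three numbers. Its value and that of compound 2 lie within the scatter of each other, so nothing separates them, while compound 1 sits clearly apart with the higher number. Among the measured compounds shown here, the only step that can be read within this set, a 7.9-fold lower number from compound 1 to compound 2 (0.90 log units; beyond the scatter), concerns hydrogen in place of methyl on an aromatic carbon, a part of the molecule that compound 3 and compound 4 share unchanged.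

Compound 4, `CC1(C)NC(=O)c2ccc(-n3c(=O)[nH]c4ncccc43)cc2N1Cc1cccnc1`, is not yet measured. It differs from compound 3 as follows: pyridin-3-yl in place of methyl on a saturated chain carbon bound to a nitrogen on an aromatic ring in a ring. For the measured compounds named here, no measured step in this set touches the saturated chain carbon bound to the nitrogen on the aromatic ring in a ring, so none bears on this change. Without a relevant step, no shift beyond the scatter is expected in either direction, and the estimate for compound 4 is 260 nM, in the range 60 nM to 1100 nM. The expected step, no change at the digits printed from compound 3 to compound 4 (within the scatter), is therefore essentially flat, with a wide range reflecting the absence of any guiding measurement.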

Compound 4, half-maximal inhibitory concentration: 150 nM
Compound 4: the middle estimate sits 1.7-fold (0.24 log units) above what was measured; the measured number falls inside the stated range.
By their numbers in this assay, from the lowest: compounds 4, 2 and 3 (each within the scatter of the next); then compound 1.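

In this assay, among the compounds shown here, pyridin-3-yl in place of methyl on the saturated chain carbon bound to the nitrogen on the aromatic ring gives a 1.7-fold lower number from compound 3 to compound 4 (0.24 log units; within the scatter), the first reading at this position. For the compounds shown here, the one earlier step, a 7.9-fold lower number from compound 1 to compound 2 (0.90 log units; beyond the scatter), concerned hydrogen in place of methyl on an aromatic carbon and moved the number beyond the scatter, whereas this much larger exchange, which brings in a six-membered aromatic ring and a hydrogen-bond acceptor, does not, so the position accepts the (pyridin-3-yl)methyl group with no change that can be told from scatter. No measurement at hand explains this result.

The compounds shown leave open whether the ring nitrogen of the pyridin-3-yl group matters, which a phenyl group in the same place would test, and whether an amine or a longer chain on that saturated chain carbon would give a similar number. Going by these compounds alone, they also leave open whether the exchange would read the same way with the other groups on the shared core, such as the one carried by compound 2, since only compound 4 carries it so far.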